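Benzyl replaces sec-butyl on the purine-type ring nitrogen

The source may hold more compounds than are shown below. What is called first, only, known or untested is meant among the compounds shown, and "the series" means these compounds.

Measured compounds:
compound 1 `CCC(C)n1cnc2c(NCc3ccc(C(=O)Nc4ccccc4N)cc3)nc(Cl)nc21`: 47.3%
compound 2 `Cc1ccc(Nc2nc(Cl)nc3c2ncn3Cc2ccc(C(=O)Nc3ccccc3N)cc2)cc1`: 67.3%
compound 3 `Nc1ccccc1NC(=O)/C=C/c1ccc(Cn2cnc3c(NC4CCCCC4)nc(Cl)nc32)cc1`: 8.09%

Of the compounds shown here, three built around a shared core have been tested in a functional assay on NCI-H460 cells (Homo sapiens) for antiproliferative activity, read by CCK-8 assay, with a stated time of 72 h, tested at 2 uM; on this read-out higher numbers stand for a stronger effect at the one concentration tested and lower numbers for a weaker effect. Compound 1 gives 47.3%, the second highest of the three numbers. Compound 2 gives 67.3%, a higher number by a gap beyond the usual scatter, while compound 3 gives 8.09%, a far lower number, also beyond the scatter. Compounds 2 and 3 differ from compound 1 in more than one place, so no single change can be tied to those gaps.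

Compound 4 `Nc1ccccc1NC(=O)c1ccc(CNc2nc(Cl)nc3c2ncn3Cc2ccccc2)cc1` has not yet been measured. It differs from compound 1 in one place: benzyl in place of sec-butyl on an aromatic nitrogen. The remainder of the molecule, including the aminophenyl benzamide portion, is unchanged. For the measured compounds named here, nothing among the measured pairs isolates this kind of exchange, so the size of its effect is unknown; a step from compound 1 to compound 4 no larger than the scatter, in either direction, is expected, with at most a slight rise. Compound 4 is therefore expected to give 50%, within 30% to 70%, an expected step of a number 2.7 percentage points higher from compound 1 to compound 4 (within the scatter).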

Compound 4, a percentage reported as inhibition, at one concentration (the size of the read-out at that concentration, not a potency): 43.8%
Compound 4: middle estimate off by 6.2 percentage points, on the high side; low and high end bracket the measured number.
By their numbers in this assay, from the lowest: compound 3; then compounds 4 and 1 (each within the scatter of the next); then compound 2.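

In this assay, for the compounds shown here, putting benzyl in place of sec-butyl on the aromatic nitrogen of the five-membered ring amounts to a number 3.5 percentage points lower from compound 1 to compound 4 (within the scatter) and gives the first single-place comparison in this set. At this position, the read-out does not separate the two groups, even though benzyl brings one six-membered aromatic ring and 7 heavy atoms where sec-butyl has no ring and 4 heavy atoms. No measurement at hand explains why the two groups read alike. The compounds shown leave open whether an amine, a carboxylic acid or a longer chain on this nitrogen would move the number beyond the scatter. Also open, as far as these compounds go, is whether the exchange of sec-butyl for benzyl would read the same way at other concentrations or with the other parts of the molecule changed.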